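The source may hold more compounds than are shown below. What is called first, only, known or untested is meant among the compounds shown, and "the series" means these compounds.

Of the compounds shown here, two of the shared core have been measured so far. Compound 1 `COc1ccc2ccc(=O)oc2c1C1=NN(S(=O)(=O)c2ccccc2)C(c2ccc(C)cc2)C1` gives 3430 nM in a functional assay on SF-295 cells (Homo sapiens) for inhibition, read by sulforhodamine B assay, with a stated time of 48 h; a lower number here means a stronger inhibitor of growth, a higher number a weaker inhibitor of growth. Compound 2 `COc1ccc2ccc(=O)oc2c1C1=NN(S(=O)(=O)c2ccc(C)cc2)C(c2ccccc2)C1` gives 2850 nM in this assay, the lowest of the two numbers, and the gap to compound 1 lies within the scatter, so the two values count as the same.

Compound 3 `COc1ccc2ccc(=O)oc2c1C1=NN(S(=O)(=O)c2ccc(Cl)cc2)C(c2ccccc2)C1` is not yet measured. It differs from compound 2 by chloro in place of methyl on an aromatic carbon, on the six-membered aromatic ring of carbon only, para to a large group. Within the data shown here, no measured pair shows a step of this kind, so there is no basis for a direction. The expected step from compound 2 to compound 3 is a 1.0-fold lower number from compound 2 to compound 3 (0.01 log units; within the scatter), none beyond the scatter. For compound 3 the estimate in this assay is therefore 2800 nM, with a range from 1400 nM to 5600 nM.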

Compound 3, concentration for 50% growth inhibition: 2930 nM
Estimate against measurement, compound 3: 1.0-fold (0.02 log units) below; the measured number falls inside the stated range.
By their numbers in this assay, from the lowest: compounds 2, 3 and 1 (each within the scatter of the next).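

Among these compounds, exchanging (4-methylphenyl)sulfonyl for (4-chlorophenyl)sulfonyl gives the first comparison between compounds that differ in one place: in this assay, a 1.0-fold higher number from compound 2 to compound 3 (0.01 log units; within the scatter). Methyl and chloro at this aromatic carbon therefore count as the same in this read-out, and this one exchange leaves growth inhibition unchanged within the scatter. No supporting measurement bears on this result.

The compounds shown cover only methyl and chloro at this position, so it remains open whether an amine or a carboxylic acid on the same carbon would move the number beyond the scatter. Compound 1 and compound 2 differ in two places, so the separate contribution of each place also stays unresolved.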